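Replacing the cyano group on the furan-3-yl compound

The source may hold more compounds than are shown below. What is called first, only, known or untested is meant among the compounds shown, and "the series" means these compounds.

Measured in a functional assay for inhibition, with Homo sapiens as the target; a higher number here means a weaker inhibitor, a lower number a stronger inhibitor:
- compound 1 `N#Cc1cc(-c2ccccc2)c2ccc(OCc3cccc(C4(O)CCOCC4)c3)cc2c1`: 3 nM
- compound 2 `N#Cc1cc(-c2ccoc2)c2ccc(OCc3cccc(C4(O)CCOCC4)c3)cc2c1`: 2 nM

For the measured compounds named here, compound 2 stands at 2 nM, within the scatter of compound 1, the only other compound measured so far. Going by the values given here, the one measured step, a 1.5-fold lower number from compound 1 to compound 2 (0.18 log units; within the scatter), concerns the exchange of phenyl for furan-3-yl and leaves the cyano group untouched.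

Compound 3 `OC1(c2cccc(COc3ccc4c(-c5ccoc5)cc(C5=NCCO5)cc4c3)c2)CCOCC1` keeps the furan-3-yl group and changes the other substituent: a group of 5 heavy atoms (3 carbon, 1 nitrogen, 1 oxygen; one five-membered non-aromatic ring with 2 hetero atoms) in place of a group of 2 heavy atoms (1 carbon, 1 nitrogen; no ring), on an aromatic carbon. A group of 5 heavy atoms thus replaces one of 2 heavy atoms on an aromatic carbon. Among the compounds with values here, no measured step covers this place, so the data give no direct size for the replacement. The step of a 1.5-fold lower number from compound 1 to compound 2 (0.18 log units; within the scatter) shows only that one other place tolerated a change of group, and it cannot be carried over with confidence. A modest move towards a higher number in this assay is therefore expected, with wide uncertainty in either direction. The expected step is a 3.0-fold higher number from compound 2 to compound 3 (0.48 log units; beyond the scatter). For compound 3 the estimated value is 6 nM, with an expected range of 1.5 nM to 30 nM.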

Compound 3, half-maximal inhibitory concentration: 3 nM
Estimate against measurement, compound 3: 2.0-fold (0.30 log units) above; measured number inside the range.
By their numbers in this assay, from the lowest: compounds 2, 1 and 3 (each within the scatter of the next).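

In this assay, the exchange of the cyano group for the five-membered non-aromatic ring with 2 hetero atoms gives a 1.5-fold higher number from compound 2 to compound 3 (0.18 log units; within the scatter), so this aromatic carbon, meta to a furan-3-yl group, accepts a group of 5 heavy atoms in place of one of 2 heavy atoms without a step beyond the scatter. With the furan-3-yl group in place, the cyano group and its triple bond are therefore not required for a number in this range: the entering group brings a ring, a double bond outside aromatic rings and 2 hydrogen-bond acceptors, and the two numbers stay within the scatter of each other. Nothing at hand gives a reason for this tolerance.

Open, from the compounds shown here alone, is how far the position stretches beyond these two groups: an amine, a carboxylic acid or a primary amide on the same aromatic carbon would test it with quite different groups. Also open is whether the five-membered ring gives a similar number when phenyl replaces furan-3-yl, a pairing not covered by the compounds shown.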